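Nitrocatechol series: pyrazoline and chalcone analogues

This account rests on a few compounds, and the source may have more. Where it says the series, first, only, none or still open, it means among the compounds named here.

All values are from an assay for inhibition of Catechol O-methyltransferase (Rattus norvegicus), read by fluorescence and spectrophotometry; on this read-out lower numbers stand for stronger inhibition and higher numbers for weaker inhibition.
compound 1 `CC(=O)N1N=C(c2cc(O)c(O)c([N+](=O)[O-])c2)CC1c1ccco1`: 180 nM
compound 2 `N#Cc1cccc(/C=C/C(=O)c2cc(O)c(O)c([N+](=O)[O-])c2)c1`: 240 nM
compound 3 `O=C(/C=C/c1cccs1)c1cc(O)c(O)c([N+](=O)[O-])c1`: 190 nM

Compound 1 has the lowest of the three numbers, but its gaps to compound 3 and to compound 2 are within the scatter, so no order among the three is claimed. Compound 4 `CC(=O)N1N=C(c2cc(O)c(O)c([N+](=O)[O-])c2)CC1c1ccc(C#N)cc1` differs from compound 1 by 4-cyanophenyl in place of furan-2-yl on a saturated ring carbon. For the measured compounds named here, no pair of measured compounds isolates this change. The only hint comes from the other scaffold: in this assay compound 2 gives 240 nM and compound 3 gives 190 nM, within the scatter of each other, so a cyanophenyl against a five-membered heteroaryl shows no clear effect there. The step from compound 1 to compound 4 is therefore expected to be a 1.1-fold higher number from compound 1 to compound 4 (0.05 log units; within the scatter), none beyond the scatter. Compound 4 is estimated at 200 nM, in the range 80 nM to 500 nM.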

Compound 4, half-maximal inhibitory concentration: 48 nM
For compound 4 the middle estimate is 4.2-fold (0.62 log units) above the measured one, outside the stated range (below it).
By their numbers in this assay, from the lowest: compound 4; then compounds 1, 3 and 2 (each within the scatter of the next).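

The saturated ring carbon next to the ring nitrogen is sensitive to its substituent: in this assay, 4-cyanophenyl in place of furan-2-yl gives a step beyond the scatter (a 3.8-fold lower number from compound 1 to compound 4 (0.57 log units; beyond the scatter)). For the compounds shown here, the earlier compounds held no pair isolating this position, and this single pair is the first direct reading of it.

From the compounds shown here alone, whether the step belongs to the nitrile or to the six-membered aromatic ring stays open; a plain phenyl, or a phenyl bearing an amine or a carboxylic acid, would separate the two. No measurement at hand accounts for the step.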